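The source may hold more compounds than are shown below. What is called first, only, known or untested is meant among the compounds shown, and "the series" means these compounds.

Compound 1 `CCSCCC12CCC(c3nnc(-c4ccccc4C(F)(F)F)n3C)(CC1)CC2` gives 79% in a functional assay on the whole organism (strain ICR) for inhibition, with Mus musculus as the target, with a stated time of 4 h, at a dose of 10 mg/kg by the oral route; a higher number here means more inhibition at the dose given (going by the name of the read-out), a lower number less inhibition. Compound 2 `Cn1c(-c2ccccc2C(F)(F)F)nnc1C12CCC(CCS(C)(=O)=O)(CC1)CC2` gives 96%. Compound 3 `Cn1c(-c2ccccc2C(F)(F)F)nnc1C12CCC(COc3ccc(S(C)(=O)=O)cc3)(CC1)CC2` gives 79%.

For the measured compounds named here, compound 3 stands level with compound 1, the two together the lowest of the three numbers; the only step beyond the scatter is a number 17 percentage points lower from compound 2 to compound 3 (beyond the scatter), while no change at the digits printed from compound 1 to compound 3 (within the scatter). Compound 4 `CCCCCC12CCC(c3nnc(-c4ccccc4C(F)(F)F)n3C)(CC1)CC2` differs from compound 3 in one place: butyl in place of 4-(methylsulfonyl)phenoxy on a saturated chain carbon bound to a saturated ring carbon. Going by the values given here, the two steps that bear on this side chain point the same way: no change at the digits printed from compound 1 to compound 3 (within the scatter) and a number 17 percentage points lower from compound 2 to compound 3 (beyond the scatter), and compound 4 keeps none of the sulfur or oxygen found in the others, so no measured step covers it directly. Compound 4 is therefore expected to change by a number 7 percentage points lower from compound 3 to compound 4 (within the scatter), within the scatter or slightly down. The estimate for compound 4 is 72%, with a range from 45% to 92%.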

Compound 4, a percentage reported as inhibition, in the whole organism at one dose (the size of the read-out at that dose, not a potency): 98%
Compound 4: middle estimate off by 26 percentage points, on the low side; the whole stated range lies below it.
By their numbers in this assay, from the lowest: compounds 1 and 3 (each within the scatter of the next); then compounds 2 and 4 (each within the scatter of the next).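

At this chain position, sulfur and oxygen are not needed for a high number in this assay: with propyl in place of methylsulfonyl there is a number 2 percentage points higher from compound 2 to compound 4 (within the scatter), so the plain chain matches the sulfone. Propyl in place of ethylsulfanyl gives a number 19 percentage points higher from compound 1 to compound 4 (beyond the scatter), and butyl in place of 4-(methylsulfonyl)phenoxy gives a number 19 percentage points higher from compound 3 to compound 4 (beyond the scatter). Nothing measured here explains these differences.

As far as these compounds go, whether an amine, a carboxylic acid or a longer chain at this place would keep the number stays open. A single dose and time also leaves potency unknown.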